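This account rests on a few compounds, and the source may have more. Where it says the series, first, only, none or still open, it means among the compounds named here.

Measured in a functional assay on MCF7 cells (Homo sapiens) for antiproliferative activity, read by MTT assay, with a stated time of 24 h; on this read-out lower numbers stand for stronger inhibition and higher numbers for weaker inhibition:
- Compound 1 `CCn1c(C(=O)N[C@H](C)C(=O)OC)ccc1C(CC)(CC)c1ccc(OCS(=O)(=O)c2ccccc2)c(C)c1`: > 50000 nM, a limit of the assay and not a number.
- Compound 2 `CCn1c(C(=O)NCCO)ccc1C(CC)(CC)c1ccc(OCS(=O)(=O)c2ccccc2)c(C)c1`: 15500 nM.

Among the measured compounds shown here, compound 2 holds the only true number so far. Compound 3 `CCn1c(C(=O)NC2(CO)CC2)ccc1C(CC)(CC)c1ccc(OCS(=O)(=O)c2ccccc2)c(C)c1` puts 1-(hydroxymethyl)cyclopropyl in place of 2-hydroxyethyl on an amide-type nitrogen. For the measured compounds named here, the one measured step at this nitrogen is an at least 3.2-fold lower number from compound 1 to compound 2 (0.50 log units; beyond the scatter). As far as these compounds go, it starts from a limit, so its full size is unknown, and it offers only a weak guide. The expected change in this assay is a 1.0-fold lower number from compound 2 to compound 3 (0.01 log units; within the scatter), with no shift beyond the scatter expected. For compound 3 the estimate is 15000 nM, with an expected range of 5000 nM to 45000 nM.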

Compound 3, half-maximal inhibitory concentration: 28800 nM
Estimate against measurement, compound 3: 1.9-fold (0.28 log units) below, and the stated range covers the measured number.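

At the amide-type nitrogen, 1-(hydroxymethyl)cyclopropyl in place of 2-hydroxyethyl gives a 1.9-fold higher number from compound 2 to compound 3 (0.27 log units; within the scatter), so this assay does not separate these two groups. The other comparison reads an at least 1.7-fold lower number from compound 1 to compound 3 (0.23 log units; that floor lies within the scatter), which leaves compound 3 not firmly separated from the 1-(methoxycarbonyl)ethyl amide. That reading rests on a limit held by compound 1, which is not a number: the limit of > 50000 nM in this assay, at which 1 of the 3 values shown sits.

As far as these compounds go, whether a carboxylic acid, a primary amine or a longer chain on this nitrogen would shift the number beyond the scatter remains open.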